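A few compounds are considered here, and "the series" means these few. Any claim that something is new, unique, unknown or untested is made for them only; others in the source may bear on it.

Compound 1 `COc1cc[nH]c1/C=C1\C(=O)Nc2ccc([N+](=O)[O-])c(N3CCC(O)CC3)c21` and compound 2 `COc1cc[nH]c1/C=C1\C(=O)Nc2ccc([N+](=O)[O-])c(N[C@H]3CC[C@H](N)C3)c21` share one core and differ only in the group on the aromatic carbon. In a functional assay on RKO cells (Homo sapiens) for antiproliferative activity, read by MTT assay, with a stated time of 5 days (on this read-out lower numbers stand for stronger inhibition and higher numbers for weaker inhibition), compound 1 sits at a limit of the assay, < 10 nM. In this assay compound 2 likewise sits at a limit, < 15 nM. The step that the two limits leave unreadable from compound 1 to compound 2 cannot be read because both values are limits the limit of < 10 nM in this assay, at which 1 of the 2 values shown sits (the limit of < 15 nM in this assay, at which 1 of the 2 values shown sits). Compound 3 `COc1cc[nH]c1/C=C1\C(=O)Nc2ccc([N+](=O)[O-])c(N3CCCC(CO)C3)c21` differs from compound 2 by 3-(hydroxymethyl)piperidin-1-yl in place of (3-aminocyclopentyl)amino on an aromatic carbon. For the measured compounds named here, no measured step bears on this change. The step that the limit leaves unreadable from compound 2 to compound 3 is expected to stay within the scatter. Compound 3 is expected to give 10 nM in this assay, with a range from 3 nM to 40 nM.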

Compound 3, half-maximal inhibitory concentration: 124 nM
The estimate for compound 3 lay 12-fold (1.09 log units) below the measured number; measured number outside the range, above it.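

In this assay, the aromatic carbon ortho to a nitro group proves sensitive to the group it carries, with an at least 8.2-fold higher number from compound 2 to compound 3 (0.91 log units; beyond the scatter) and an at least 12-fold higher number from compound 1 to compound 3 (1.09 log units; beyond the scatter). The second step shows that a piperidin-1-yl group bearing a hydroxyl does not by itself preserve the activity of compound 1. Nothing measured here accounts for these steps.

The step between compound 1 and compound 2 cannot be read, as both values are limits. As far as these compounds go, it remains open whether a 3-aminopiperidin-1-yl group, with an amine on the ring in place of hydroxymethyl, would restore activity.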